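Compound 3: a small change in the carboxy chain

This account rests on a few compounds, and the source may have more. Where it says the series, first, only, none or still open, it means among the compounds named here.

Compound 1 (`CC(C)Oc1ccc(/N=c2\[nH]c(=O)n(C[C@@H](C)C(=O)O)c(=O)n2Cc2ccc(Cl)cc2)cc1Cl`) and compound 2 (`CC(C)Oc1ccc(/N=c2\[nH]c(=O)n(C[C@H](C)C(=O)O)c(=O)n2Cc2ccc(Cl)cc2)cc1Cl`) share one core and one side chain, and the carbon in that chain that carries the methyl branch is drawn in opposite configurations. In an ADME assay on the whole organism (plasma, Rattus norvegicus) for protein binding, using cassette dosing, at a dose of 1 mg/kg (a higher number here means a larger unbound share of the compound, a lower number a smaller unbound share), compound 1 gives 0.002 and compound 2 gives 0.003. Compound 2 therefore stands level with compound 1, and only a very small share of either compound circulates unbound.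

Compound 3 (`CC(C)Oc1ccc(/N=c2\[nH]c(=O)n(CC(C)(C)C(=O)O)c(=O)n2Cc2ccc(Cl)cc2)cc1Cl`) keeps the core but carries 1-carboxy-1-methylethyl in place of the 1-carboxyethyl of compound 2, on a saturated chain carbon bound to an aromatic nitrogen: 1-carboxy-1-methylethyl in place of 1-carboxyethyl on a saturated chain carbon bound to an aromatic nitrogen.

Within the data shown here, only one measured step bears on this change, and it concerns the same 1-carboxyethyl group. That step is a 1.5-fold higher number from compound 1 to compound 2 (0.18 log units; within the scatter), and it reflects (the fact that compounds 1 and 2 differ only in the configuration as drawn). It says nothing direct about an added group, so it is weak guidance, but it gives no sign of a large effect in this part of the molecule. The expected change is no larger than the scatter, and the estimated step is a 1.5-fold lower number from compound 2 to compound 3 (0.18 log units; within the scatter). For compound 3 the estimate is 0.002, with an expected range from 0.001 to 0.005.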

Compound 3, unbound fraction: 0.003
The estimate for compound 3 lay 1.5-fold (0.18 log units) below the measured number; measured number inside the range.
By their numbers in this assay, from the lowest: compounds 1, 2 and 3 (each within the scatter of the next).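

Adding a second methyl group to the chain gives 1-carboxy-1-methylethyl and removes the defined stereocentre, yet in this assay the result is no change at the digits printed from compound 2 to compound 3 (within the scatter) and a 1.5-fold higher number from compound 1 to compound 3 (0.18 log units; within the scatter). The earlier pair showed only that swapping the drawn configuration at this carbon leaves the number within the scatter; compound 3 extends this to a chain with one more carbon and no defined stereocentre there, so for these three compounds neither the configuration nor the extra methyl group separates the numbers, and the unbound share stays very small throughout. Nothing measured here gives a reason for this flat result.

All three compounds keep the carboxylic acid on a short branched chain and share the same core, so this small set tests only a narrow kind of change at this place. On these data alone, whether a primary amide or an amine in place of the carboxylic acid, or a longer chain between the acid and the aromatic nitrogen, would move the unbound share beyond the scatter remains open.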